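The source may hold more compounds than are shown below. What is called first, only, known or untested is meant among the compounds shown, and "the series" means these compounds.

Within the data shown here, in an ADME assay on the whole organism (strain Sprague-Dawley) for pharmacokinetics, with Rattus norvegicus as the target, at a dose of 10 mg/kg by the oral route (a higher number here means more compound in the circulation at the dose given, a lower number less compound in the circulation), compound 2 `O=C(NOCCO)c1cc2ccoc2c(F)c1Nc1ccc(I)cc1F` gives 4380 nM, the highest of the numbers measured so far. Among the measured compounds shown here, the only other measured compound, compound 1 `O=C(NOC[C@H](O)CO)c1cc2ccoc2c(F)c1Nc1ccc(I)cc1F`, gives 1380 nM. Compound 3 `O=C(NOC(CO)CO)c1cc2ccoc2c(F)c1Nc1ccc(I)cc1F` differs from compound 2 by one change: hydroxymethyl in place of hydrogen on a saturated chain carbon bound to an oxygen and a saturated chain carbon. In words, this is hydroxymethyl in place of hydrogen on a saturated chain carbon bound to an oxygen and a saturated chain carbon. For the measured compounds named here, the one measured step that bears on this is a 3.2-fold higher number from compound 1 to compound 2 (0.50 log units; beyond the scatter), in which hydrogen took the place of hydroxymethyl on a different carbon of the chain. Read in reverse, it points to a lower number in this assay, though a single step at another carbon is thin evidence. The expected change is a 2.9-fold lower number from compound 2 to compound 3 (0.47 log units; beyond the scatter). For compound 3 the estimated value is 1500 nM, with an expected range of 550 nM to 4200 nM.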

Compound 3, maximal plasma concentration: 26900 nM
Beside the measured number, compound 3's estimate is 18-fold (1.25 log units) below it, and the stated range ends below it.
By their numbers in this assay, from the lowest: compound 1; then compound 2; then compound 3.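

In this assay, hydroxymethyl in place of hydrogen on the saturated chain carbon bound to an oxygen gives a 6.1-fold higher number from compound 2 to compound 3 (0.79 log units; beyond the scatter), whereas hydroxymethyl on the other chain carbon goes with a lower number, as a 3.2-fold higher number from compound 1 to compound 2 (0.50 log units; beyond the scatter) shows when read in reverse. The direction of this change therefore depends on where the group sits on the chain, and 2-hydroxy-1-(hydroxymethyl)ethyl in place of 2,3-dihydroxypropyl on the oxygen gives a 19-fold higher number from compound 1 to compound 3 (1.29 log units; beyond the scatter). No measurement offered here accounts for this difference between the two chains. Going by these compounds, it remains open whether a methyl or an amine on the same chain carbon would also go with a higher number. A longer chain, such as 3-hydroxypropyl in place of 2-hydroxyethyl, is likewise an open case.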